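Thiophen-2-yl to furan-2-yl swap: estimate for compound 3

A few compounds are considered here, and "the series" means these few. Any claim that something is new, unique, unknown or untested is made for them only; others in the source may bear on it.

Measured so far in a functional assay on T47D cells (Homo sapiens) for cytotoxicity, read by CCK-8 assay and cell counting, with a stated time of 2 days; a lower number here means a stronger inhibitor, a higher number a weaker inhibitor:
compound 1 `Oc1ccc(-c2cc(-c3cccs3)nc(-c3ccccc3Cl)c2)cc1`: 5870 nM
compound 2 `Oc1ccc(-c2cc(-c3cccc(Cl)c3)nc(-c3cccs3)c2)cc1`: 5350 nM

Among the measured compounds shown here, compound 2 stands alongside compound 1, the two within the scatter of each other; the single measured step, a 1.1-fold lower number from compound 1 to compound 2 (0.04 log units; within the scatter), is small. Compound 3 `Oc1ccc(-c2cc(-c3cccc(Cl)c3)nc(-c3ccco3)c2)cc1` differs from compound 2 by furan-2-yl in place of thiophen-2-yl on an aromatic carbon. For the measured compounds named here, no measured step bears directly on this exchange; the one recorded step concerns the chlorophenyl substitution pattern and stayed within the scatter. The swap is therefore expected to move this assay little, with no clear direction, so a step of a 1.0-fold higher number from compound 2 to compound 3 (0.01 log units; within the scatter) is expected. Compound 3 is estimated at 5500 nM in this assay, range 2500 nM to 12000 nM.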

Compound 3, half-maximal inhibitory concentration: 5220 nM
The estimate for compound 3 lay 1.1-fold (0.02 log units) above the measured number, and the stated range covers the measured number.
By their numbers in this assay, from the lowest: compounds 3, 2 and 1 (each within the scatter of the next).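

Among the compounds shown here, the first reading at this place, next to the ring nitrogen, comes from the exchange of thiophen-2-yl for furan-2-yl: in this assay, a 1.0-fold lower number from compound 2 to compound 3 (0.01 log units; within the scatter). The two five-membered aromatic rings, which differ in the sulfur and oxygen hetero atoms, are thus not told apart in this assay. No supporting measurement bears on this result.

The compounds shown leave open whether an amine, a carboxylic acid or a longer chain at this place would give a number beyond the scatter of these values.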